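A few compounds are considered here, and "the series" means these few. Any claim that something is new, unique, unknown or untested is made for them only; others in the source may bear on it.

For the measured compounds named here, compound 2 `COc1ccc(-c2ccc3c(c2)C(=O)C(=O)N3Cc2ccccc2OC)cc1` gives 130 nM in a functional assay on HepG2 cells (Homo sapiens) for antiproliferative activity, read by MTT assay, with a stated time of 48 h (a higher number here means a weaker inhibitor, a lower number a stronger inhibitor), the lowest of the two numbers so far; its nearest neighbour is compound 1 `COc1ccc(-c2ccc3c(c2)C(=O)C(=O)N3Cc2cccc(OC)c2)cc1`, which in this assay gives 700 nM, and the step of a 5.4-fold lower number from compound 1 to compound 2 (0.73 log units; beyond the scatter) is the only measured one. Compound 3 `COc1ccc(-c2ccc3c(c2)C(=O)C(=O)N3Cc2ccc3ccccc3c2)cc1` is obtained from compound 2 by naphthalen-2-yl in place of 2-methoxyphenyl on a saturated chain carbon bound to an amide-type nitrogen in a ring. Going by the values given here, the one measured step concerns the same place but a different change, so it bears on it only loosely. Compound 3 is therefore expected to show a 2.3-fold higher number from compound 2 to compound 3 (0.36 log units; beyond the scatter) from compound 2, with the estimate for compound 3 being 300 nM and a range from 80 nM to 1200 nM.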

Compound 3, half-maximal inhibitory concentration: 380 nM
The estimate for compound 3 lay 1.3-fold (0.10 log units) below the measured number; low and high end bracket the measured number.
By their numbers in this assay, from the lowest: compound 2; then compounds 3 and 1 (each within the scatter of the next).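

At this place, on a saturated chain carbon bound to an amide-type nitrogen in a ring, naphthalen-2-yl in place of 2-methoxyphenyl gives a 2.9-fold higher number from compound 2 to compound 3 (0.47 log units; beyond the scatter) and so does not match the methoxyphenyl group of compound 2. In place of 3-methoxyphenyl, the same group gives a 1.8-fold lower number from compound 1 to compound 3 (0.27 log units; within the scatter) and so leaves compound 3 and compound 1 unordered, with only compound 2 standing apart from both. Nothing available accounts for these differences. Left open is whether the methoxy group of compound 2 matters as such: a plain phenyl group, or a phenyl group carrying a hydroxyl or an amine instead, would show this.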